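Bromo oxazole series: methoxy for methylsulfanyl

The compounds below may be only part of what the source reports. "The series", "measured", "known", "first", "only" and "open" are said of these compounds alone.

In a functional assay on A549 cells (Homo sapiens) for cytotoxicity, read by MTT assay, with a stated time of 48 h (a lower number here means a stronger inhibitor, a higher number a weaker inhibitor), compound 1 `COc1cc(-c2ocnc2-c2cc(Br)c(OC)c(OC)c2)ccc1SC` gives > 20000 nM, which is a limit and not a number. Compound 2 `COc1ccc(-c2ocnc2-c2cc(Br)c(OC)c(OC)c2)cc1SC` gives > 20000 nM in this assay, again a limit. Compound 3 `COc1ccc(-c2c(-c3cc(OC)c(SC)c(OC)c3)ncn2C)cc1O` gives > 20000 nM in this assay, also a limit. The series therefore reads as the limit of > 20000 nM in this assay, at which 3 of the 3 values shown sit. Compound 2 has no numerical value and stands only at this limit, alongside the other two compounds.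

Compound 4 `COc1ccc(-c2ocnc2-c2cc(Br)c(OC)c(OC)c2)cc1OC` differs from compound 2 by methoxy in place of methylsulfanyl on an aromatic carbon, ortho to a methoxy group and meta to a large group: methoxy in place of methylsulfanyl on an aromatic carbon.

Among the compounds with values here, the series contains no measured step between compounds differing in one place, so the size of this change cannot be read from the data. In this assay, the expectation is for no shift beyond the scatter in either direction, and a result reported only as a limit is the likeliest outcome. Within the data shown here, this expectation rests on the single exchange of methylsulfanyl for methoxy and on compound 2 giving > 20000 nM. In estimated terms, the change is a number no higher from compound 2 to compound 4 (the limit leaves the size open). The expected value for compound 4 is 20000 nM, with an estimated range from 7000 nM to 60000 nM.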

Compound 4, half-maximal inhibitory concentration: 500 nM
Beside the measured number, compound 4's estimate is 40-fold (1.60 log units) above it; the measured number lies below the stated range.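

Working note on the methylsulfanyl position: in this assay, the exchange for methoxy on the aromatic carbon ortho to a methoxy group and meta to a large group gives an at least 40-fold lower number from compound 2 to compound 4 (1.60 log units; beyond the scatter), so a single change on this ring is enough to move the series off its limit. The same exchange starting from compound 1 gives an at least 40-fold lower number from compound 1 to compound 4 (1.60 log units; beyond the scatter), which means that compound 4 stands apart from both methylsulfanyl compounds on the oxazole core, whichever of the two ring carbons carries the methylsulfanyl group. Compound 4 is the only compound in the series with a numerical value: the limit of > 20000 nM in this assay, at which 3 of the 4 values shown sit.

The compounds shown do not tell whether the gain is specific to methoxy, since no ethoxy, hydroxyl or amine at this carbon stands beside compound 4 for comparison. Within the data shown here, also open is how much of the value of compound 4, 500 nM, depends on the bromine on the other aromatic ring, as no analogue with chlorine or hydrogen in its place appears here.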